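Benzyl ether series: cytotoxicity stays at the limit

A few compounds are considered here, and "the series" means these few. Any claim that something is new, unique, unknown or untested is made for them only; others in the source may bear on it.

Compound 1 `O=c1c(O)c(-c2ccccc2)oc2cc(OCc3ccccc3Br)cc(O)c12` and compound 2 `COc1cccc(COc2cc(O)c3c(=O)c(O)c(-c4ccccc4)oc3c2)c1` differ only in the benzyl group. In an ADME assay on Huh-5-2 cells (Homo sapiens) for cytotoxicity, read by WST assay, with a stated time of 3 days (a lower number here means that less compound is tolerated, a higher number that more compound is tolerated), compound 1 gives only a limit, > 100000 nM. In this assay compound 2 likewise gives only a limit, > 100000 nM. The step that the two limits leave unreadable from compound 1 to compound 2 thus has no readable size, a consequence of the limit of > 100000 nM in this assay, at which 2 of the 2 values shown sit. Compound 3 `Cc1ccc(COc2cc(O)c3c(=O)c(O)c(-c4ccccc4)oc3c2)cc1` carries 4-methylphenyl in place of 3-methoxyphenyl on a saturated chain carbon bound to an oxygen on an aromatic ring. Within the data shown here, the only step bearing on this change is unreadable, so in this assay no step beyond the scatter is expected, a step that the limit leaves unreadable from compound 2 to compound 3. Compound 3 is expected to give 150000 nM, within 60000 nM to 500000 nM, most likely again only as a limit.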

Compound 3, half-maximal cytotoxic concentration: 88000 nM
Compound 3: the middle estimate sits 1.7-fold (0.23 log units) above what was measured; the range from low to high includes it.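

Among these compounds, with 4-methylphenyl on this saturated chain carbon, compound 3 gives the first value at this position that is a number and not a limit in this assay. The steps read as an at least 1.1-fold lower number from compound 2 to compound 3 (0.05 log units; that floor lies within the scatter) and an at least 1.1-fold lower number from compound 1 to compound 3 (0.05 log units; that floor lies within the scatter); both are floors only, so neither shows a real difference among the three benzyl groups. The rest of the series still gives no size: the limit of > 100000 nM in this assay, at which 2 of the 3 values shown sit.

On these data alone, how far the values of compound 1 and compound 2 actually lie from that of compound 3 stays open. So does whether an amine or a carboxylic acid in place of 4-methylphenyl would give a clearly lower number in this assay.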